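Methoxy for Fluoro on the Aryl Ring of Compound 2

This account rests on a few compounds, and the source may have more. Where it says the series, first, only, none or still open, it means among the compounds named here.

Compound 2, `C=CC1=C(C(=O)NCc2ccccc2F)C(c2ccc(F)cc2)OC1`, was tested in a functional assay on SW480 cells (Homo sapiens) for cytotoxicity, read by MTT assay, with a stated time of 24 h; on this read-out higher numbers stand for weaker inhibition and lower numbers for stronger inhibition. In this assay compound 2 gives > 100000 nM, which is a limit of the assay and not a number. Compound 1, `C=CC1=C(C(=O)NCCC)C(c2ccc(F)cc2)OC1`, likewise returns only a limit in this assay, > 100000 nM. Compound 3, `C=CC1=C(C(=O)Nc2ccc(C)cc2)C(c2ccc(F)cc2)OC1`, also stands at a limit in this assay, giving > 100000 nM. The steps among these three compounds, a step that the two limits leave unreadable from compound 1 to compound 2, a step that the two limits leave unreadable from compound 1 to compound 3 and a step that the two limits leave unreadable from compound 2 to compound 3, cannot be read in size, because all three measurements share (the limit of > 100000 nM in this assay, at which 3 of the 3 values shown sit).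

The unmeasured compound 4, `C=CC1=C(C(=O)NCc2ccccc2F)C(c2ccc(OC)cc2)OC1`, differs from compound 2 as follows: methoxy in place of fluoro on an aromatic carbon. For the measured compounds named here, none of the measured steps touches this aromatic carbon: each of them changes the group on the amide-type nitrogen side of the shared core, and none has a readable size. The three measurements give no ground for expecting a step in either direction beyond the scatter. In this assay the step that the limit leaves unreadable from compound 2 to compound 4 is therefore expected to be no larger than the scatter. Compound 4 is estimated at 150000 nM, with a range from 50000 nM to 600000 nM. The most likely outcome is that compound 4 is again reported only as a limit.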

Compound 4, half-maximal inhibitory concentration: > 100000 nM
Compound 4: a limit, no number; the forecaster's own chance of this, stated with the estimate: 80%; the middle value does not contradict the limit.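

No new step can be read between compound 2 and compound 4 in this assay, because the two compounds share one limit: the limit of > 100000 nM in this assay, at which 4 of the 4 values shown sit.

The compounds shown leave open how far any of them lies from that limit, and whether 4-methoxyphenyl in place of 4-fluorophenyl changes the read-out in this assay at all.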